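The source may hold more compounds than are shown below. What is called first, only, known or untested is meant among the compounds shown, and "the series" means these compounds.

The study concerns three measured compounds and one that has not yet been tested, all in a functional assay on HEK293 cells for antagonist activity at metabotropic glutamate receptor 5 (Rattus norvegicus), read by calcium flux; on this read-out lower numbers stand for stronger inhibition and higher numbers for weaker inhibition. Compound 1 `Cc1nc(C#Cc2cc(Cl)cc(C#N)c2)cs1` gives 1.61 nM in this assay. Compound 2 `Cc1nc(C#Cc2cc(Br)cc(C#N)c2)cs1` gives 1.06 nM in this assay. Compound 3 `Cc1ccc(C#Cc2cc(Cl)cc(C#N)c2)nc1` gives 1.22 nM in this assay. Compound 4 `Cc1ccc(C#Cc2cc(Br)cc(C#N)c2)nc1` remains to be measured in this assay.

Compound 1 and compound 2 differ at a single place: bromo in place of chloro on an aromatic carbon. That step came out as a 1.5-fold lower number from compound 1 to compound 2 (0.18 log units; within the scatter). Compound 1 and compound 3 carry different cores; the difference between the two cores is not broken down here. Among the measured compounds shown here, compound 3 and compound 4 differ by a change of the same kind as the one between compound 1 and compound 2: bromo in place of chloro on an aromatic carbon. The surroundings of the place are not described word for word alike: in compound 1 the carbon is meta to a group of 8 heavy atoms, in compound 3 it is meta to a group of 9 heavy atoms, so the two changes are of the same kind rather than the same.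

The expectation for compound 4 rests on the step of a 1.5-fold lower number from compound 1 to compound 2 (0.18 log units; within the scatter) seen on the other core. Set beside that step, the move from compound 3 to compound 4 is expected to be of similar size, a 1.4-fold lower number from compound 3 to compound 4 (0.13 log units; within the scatter). Compound 4 is therefore estimated at 0.9 nM in this assay, with an expected range from 0.4 nM to 2 nM.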

Compound 4, half-maximal inhibitory concentration: 1.02 nM
For compound 4 the middle estimate is 1.1-fold (0.05 log units) below the measured one; the measured number falls inside the stated range.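

In this assay, bromo in place of chloro on an aromatic carbon gives a 1.2-fold lower number from compound 3 to compound 4 (0.08 log units; within the scatter), and this step can be set beside the same change on the other core: the same change on two cores in this assay, a 1.5-fold lower number (0.18 log units; within the scatter) from compound 1 to compound 2 and a 1.2-fold lower number (0.08 log units; within the scatter) from compound 3 to compound 4, 1.3-fold (0.10 log units) apart, within the scatter of two such steps In this pair of cores the change therefore carries over in the limited sense that neither step can be told from the scatter, and the two steps cannot be told from each other. This does not show that bromo and chloro differ at all in this assay: each step lies within the scatter, and agreement on two cores gives no rule for a third.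

The compounds shown leave open what happens when a group other than these two halogens takes the same place, for example a methoxy group, an amine or a carboxylic acid, any of which might give a step large enough to read beyond the scatter. They also leave open whether the cyano group can give way to an amide, and whether a longer chain such as ethyl can stand in place of the methyl on either core.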